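Bromo to iodo at the aromatic carbon: working notes

The source may report more compounds than this note shows. Statements on the series, on what has been measured and on what is new or still open speak of the compounds shown alone.

Measured so far:
compound 1 `Cc1ccc(NC(=O)/C=C/c2ccccc2)c(C(N)=O)c1` gives 7590 nM in a functional assay on Malme-3M cells (Homo sapiens) for inhibition, read by sulforhodamine B assay, with a stated time of 48 h; a higher number here means a weaker inhibitor of growth, a lower number a stronger inhibitor of growth
compound 2 `NC(=O)c1cc(Br)ccc1NC(=O)/C=C/c1ccccc1` gives 1210 nM in this assay

Among the measured compounds shown here, compound 2 holds the lowest of the two numbers in this assay; compound 1 is its only neighbour, and the step of a 6.3-fold lower number from compound 1 to compound 2 (0.80 log units; beyond the scatter) is the single measured step in the set. The next compound, compound 3 `NC(=O)c1cc(I)ccc1NC(=O)/C=C/c1ccccc1`, differs from compound 2 as follows: iodo in place of bromo on an aromatic carbon. For the measured compounds named here, the only step that bears on it is a 6.3-fold lower number from compound 1 to compound 2 (0.80 log units; beyond the scatter), where a halogen entered in place of methyl and the number fell clearly beyond the scatter. Going from bromo to iodo is a smaller change than that one, and no second comparison between two halogens exists in the set. Expectation for compound 3 in this assay: a step of a 1.5-fold lower number from compound 2 to compound 3 (0.18 log units; within the scatter), at the edge of the scatter, toward a lower number. Compound 3 is estimated at 800 nM, with a range from 300 nM to 2500 nM.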

Compound 3, concentration for 50% growth inhibition: 1600 nM
Compound 3: middle estimate off by 2.0-fold (0.30 log units), on the low side, and the stated range covers the measured number.
By their numbers in this assay, from the lowest: compounds 2 and 3 (each within the scatter of the next); then compound 1.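

In this assay, exchanging bromo for iodo, para to a large group and meta to a carbamoyl group, gives a 1.3-fold higher number from compound 2 to compound 3 (0.12 log units; within the scatter), so the two halogens cannot be told apart at this position. Iodo in place of methyl gives a 4.7-fold lower number from compound 1 to compound 3 (0.68 log units; beyond the scatter), which shows that the clear gap from methyl is not confined to bromo but holds for both halogens in the set. Nothing available explains this result or the gap from methyl.

On these data alone, whether chloro or fluoro would sit with bromo and iodo, and whether an amine, a methoxy group or a nitrile at the same carbon would fall with the halogens or with methyl, remains open. Also open, as far as these compounds go, is whether the halogen gap survives when the carbamoyl group gives way to a carboxylic acid.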